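The compounds below may be only part of what the source reports. "The series", "measured", "known", "first", "only" and "open" are said of these compounds alone.

Among the measured compounds shown here, compound 2 `COc1ccc2c(NC3CCCCCC3)nc(N3CCC(N4CCCC4)CC3)nc2c1` gives 10% in an in vitro functional assay on B300-19 cells for antagonist activity at C-C chemokine receptor type 4 (Homo sapiens), read by GTPgammaS binding, tested at 1 uM (a lower number here means less inhibition, a higher number more inhibition at the concentration tested (going by the name of the read-out)), standing lowest of the two numbers recorded, though its only neighbour, compound 1 `COc1cc2nc(NCc3ccccc3)nc(NC3CCCCCC3)c2cc1OC`, gives 13% in this assay, a reading within the scatter of that of compound 2. Compound 3 `c1ccc2c(NC3CCCCCC3)nc(N3CCC(N4CCCC4)CC3)nc2c1` differs from compound 2 by hydrogen in place of methoxy on an aromatic carbon. For the measured compounds named here, no pair of measured compounds shows this change, so the expectation rests on these two readings alone. The step of no change at the digits printed from compound 2 to compound 3 (within the scatter) is expected to be none beyond the scatter. Compound 3 is estimated at 10% in this assay, with a range from 0% to 25%.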

Compound 3, a percentage reported as inhibition, at one concentration (the size of the read-out at that concentration, not a potency): 10%
Compound 3: the middle estimate sits on the measured number at the digits printed, and the stated range covers the measured number.
By their numbers in this assay, from the lowest: compounds 2, 3 and 1 (each within the scatter of the next).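

In this assay, among the compounds shown here, hydrogen in place of methoxy on an aromatic carbon gives no change at the digits printed from compound 2 to compound 3 (within the scatter) and this is the first direct reading of a change at this position. On this compound pair, the methoxy group, meta to a fused ring and para to a fused ring, can be removed without a shift beyond the scatter. No measurement at hand offers an explanation for this result. Going by these compounds, whether an amine, a carboxylic acid or a longer chain at this position would shift the reading remains open. So does whether hydrogen in place of methoxy would read the same way on another compound.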